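Methyl to methoxy on two amide-linked cores

The source may hold more compounds than are shown below. What is called first, only, known or untested is meant among the compounds shown, and "the series" means these compounds.

Compound 1 `COC(=O)[C@H](CC(C)C)NC(=O)c1ccc(OC[C@@H]2COc3ccccc3O2)cc1-c1ccccc1C` and compound 2 `COC(=O)[C@H](CC(C)C)NC(=O)c1ccc(OC[C@@H]2COc3ccccc3O2)cc1-c1ccccc1OC` share one core; compound 3 `COC(=O)[C@H](CC(C)C)NC(=O)c1ccc(C(=O)NC[C@H]2COc3ccccc3O2)cc1-c1ccccc1C` and compound 4 `COC(=O)[C@H](CC(C)C)NC(=O)c1ccc(C(=O)NC[C@H]2COc3ccccc3O2)cc1-c1ccccc1OC` share another. In a functional assay (HSMC cells, Homo sapiens) for antiproliferative activity, with a stated time of 72 h (a higher number here means a weaker inhibitor, a lower number a stronger inhibitor), compound 1 gives 5200 nM, and compound 2 gives 17000 nM. The change between them, (methoxy in place of methyl on an aromatic carbon), made the step of a 3.3-fold higher number from compound 1 to compound 2 (0.51 log units; beyond the scatter). In this assay compound 3 gives 103000 nM, the highest of the three measured numbers; the difference between the core of compound 3 and the core of compound 1 is not broken down here. Compound 4 carries the same change on the core of compound 3: methoxy in place of methyl on an aromatic carbon. Among the compounds with values here, the only precedent is the single pair of compound 1 and compound 2, so the expectation for compound 4 rests on one step and on a core whose response to this change is unmeasured. The step from compound 3 to compound 4 is expected to be about a 2.9-fold higher number from compound 3 to compound 4 (0.46 log units; beyond the scatter), taken from the size of a 3.3-fold higher number from compound 1 to compound 2 (0.51 log units; beyond the scatter). For compound 4 in this assay the expected value is 300000 nM, between 100000 nM and 900000 nM. Compound 3 already gives 103000 nM, the highest number measured here, so the estimate for compound 4 lies further out still and rests on a single precedent.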

Compound 4, half-maximal inhibitory concentration: 185000 nM
Beside the measured number, compound 4's estimate is 1.6-fold (0.21 log units) above it; the range from low to high includes it.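

In this assay, 2-methylphenyl to 2-methoxyphenyl on the core of compound 3 gives a 1.8-fold higher number from compound 3 to compound 4 (0.25 log units; within the scatter), so on this core the step alone cannot be told apart from repeat-measurement noise. Set beside the step on the core of compound 1, the two sizes cannot be told apart either: the same change on two cores in this assay, a 3.3-fold higher number (0.51 log units; beyond the scatter) from compound 1 to compound 2 and a 1.8-fold higher number (0.25 log units; within the scatter) from compound 3 to compound 4, 1.8-fold (0.26 log units) apart, within the scatter of two such steps

Within the data shown here, this shows that the results fit a change that carries from one core to the other at a similar size, with the number in the same direction on both, but it does not establish transfer: only one of the two steps stands clear of the scatter, and each core rests on a single pair.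

Open, on these data alone, is whether a hydroxy group or a chlorine atom on the same aromatic carbon, ortho to a large group, would move the number in the same way on both cores. Also open, as far as these compounds go, is whether a carboxylic acid in place of the methyl ester would alter the size of the step from methyl to methoxy.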